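The source may hold more compounds than are shown below. What is called first, only, known or untested is meant among the compounds shown, and "the series" means these compounds.

Working notes on the series. Compound 2 `O=C(Nc1ccc2ncnc(Nc3cccc(Br)c3)c2c1)C1COc2ccccc2O1` carries the 2,3-dihydro-1,4-benzodioxin-2-yl group on a carbonyl carbon whose other neighbour is an amide-type nitrogen. In a functional assay on MCF7 cells (Homo sapiens) for antiproliferative activity, read by WST assay, with a stated time of 48 h (a lower number here means a stronger inhibitor, a higher number a weaker inhibitor), compound 2 reaches only the assay limit, > 100 ug/mL, so no number is known for it. Compound 3 `O=C(Nc1ccc2ncnc(Nc3cccc(Cl)c3)c2c1)C1COc2ccccc2O1` differs by chloro in place of bromo on an aromatic carbon; in this assay compound 3 gives 52.2 ug/mL. The step of an at least 1.9-fold lower number from compound 2 to compound 3 (0.28 log units; that floor lies within the scatter) is the only one that rests on two compounds differing in a single place. For the measured compounds named here, compound 1 `Clc1cccc(Nc2ncnc3ccc(NCc4ccc5c(c4)OCCCCO5)cc23)c1`, built on a different linker, gives 21.3 ug/mL in this assay; no single-change step joins it to the others, so its value only shows where this shared core can reach.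

Compound 4 `O=C(Nc1ccc2ncnc(Nc3cccc(Br)c3)c2c1)c1cccc2c1OCCO2` is not yet measured. It differs from compound 2 by 2,3-dihydro-1,4-benzodioxin-5-yl in place of 2,3-dihydro-1,4-benzodioxin-2-yl on a carbonyl carbon. Going by the values given here, none of the measured steps touches this part of the molecule, so no measured step bears on the change; the halogen step from compound 2 to compound 3 speaks to a different position. With compound 2 at a limit, (the limit of > 100 ug/mL in this assay, at which 1 of the 3 values shown sits), the direction of the change cannot be read from the data.

The step of an at least 1.1-fold lower number from compound 2 to compound 4 (0.04 log units; that floor lies within the scatter) is therefore expected to stay within the scatter. For compound 4 the estimate in this assay is 90 ug/mL, with a range from 35 ug/mL to 230 ug/mL.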

Compound 4, half-maximal inhibitory concentration: 59.5 ug/mL
For compound 4 the middle estimate is 1.5-fold (0.18 log units) above the measured one, and the stated range covers the measured number.
By their numbers in this assay, from the lowest: compound 1; then compounds 3 and 4 (each within the scatter of the next). At a limit, above all of these: compound 2.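

For the compounds shown here, of the steps so far, this is the only one that touches the group on the carbonyl carbon: in this assay, 2,3-dihydro-1,4-benzodioxin-5-yl in place of 2,3-dihydro-1,4-benzodioxin-2-yl gives an at least 1.6-fold lower number from compound 2 to compound 4 (0.22 log units; that floor lies within the scatter). The two groups have the same atoms and the same ring counts, so this step concerns only how the same group is joined to the carbonyl carbon, and with bromo kept, compound 4 gives a real number at 59.5 ug/mL. The size of the step remains a floor that lies within the scatter, since compound 2 is only a limit: the limit of > 100 ug/mL in this assay, at which 1 of the 4 values shown sits.

Going by these compounds, whether the true gap between these two attachments lies beyond the scatter remains open, as does whether the same change would hold with chloro in place of bromo on an aromatic carbon. Also open, on these data alone, is what a simple phenyl or an aminomethyl group on the carbonyl carbon, in place of 2,3-dihydro-1,4-benzodioxin-5-yl, would give in this assay.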